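Swapping a Nitro for a Hydroxy on the Biaryl Arm

This account rests on a few compounds, and the source may have more. Where it says the series, first, only, none or still open, it means among the compounds named here.

For the measured compounds named here, compound 3 `CN(CC1=CC[C@H]2C[C@@H]1C2(C)C)Cc1ccc(-c2cccc([N+](=O)[O-])c2)cc1` holds the lowest of the two numbers so far in an assay on HEK293 cells for displacement of a labelled ligand from C-X-C chemokine receptor type 3 (Homo sapiens) (a higher number here means a weaker inhibitor, a lower number a stronger inhibitor), where compound 3 gives 2000 nM. Its nearest neighbour is compound 1 `CN(CC1=CC[C@H]2C[C@@H]1C2(C)C)Cc1ccc(-c2ccccc2)cc1`, the parent with an unsubstituted outer ring, which in this assay gives 3160 nM; the step of a 1.6-fold lower number from compound 1 to compound 3 (0.20 log units; within the scatter), nitro in place of hydrogen on an aromatic carbon, stays within the scatter. Compound 2 `CC(=O)c1cccc(-c2ccc(CN(C)CC3=CC[C@H]4C[C@@H]3C4(C)C)cc2)c1`, carrying an acetyl at that position, is known in this assay only as a limit, > 316 nM. That limit of > 316 nM in this assay, at which 1 of the 3 values shown sits, leaves the steps a step that the limit leaves unreadable from compound 1 to compound 2 and a step that the limit leaves unreadable from compound 2 to compound 3 without a readable size.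

Compound 4 `CN(CC1=CC[C@H]2C[C@@H]1C2(C)C)Cc1ccc(-c2cccc(O)c2)cc1` differs from compound 3 by hydroxy in place of nitro on an aromatic carbon. Going by the values given here, no measured step exchanges a nitro for a hydroxy, so the closest guidance is indirect: the one readable step, a 1.6-fold lower number from compound 1 to compound 3 (0.20 log units; within the scatter), shows that placing a nitro on this ring changed the number little, and the two other steps cannot be read. The step of no change at the digits printed from compound 3 to compound 4 (within the scatter) is therefore expected to stay within the scatter, with no clear direction. Compound 4 is estimated in this assay at 2000 nM, in a range from 800 nM to 5000 nM.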

Compound 4, inhibition constant: > 316 nM
Compound 4 gave a limit, no number (the forecaster's own chance of this, stated with the estimate: 20%); the middle value does not contradict the limit.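

In this assay compound 4 is known only as a limit, > 316 nM, so the steps linking it to compound 1, compound 2 and compound 3 cannot be read. Compound 2 shares that limit: the limit of > 316 nM in this assay, at which 2 of the 4 values shown sit.

As far as these compounds go, what stays open is where compound 2 and compound 4 stand relative to compound 1 and compound 3, and whether an acetyl or hydroxy on the outer ring changes the number at all.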